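The source may report more compounds than this note shows. Statements on the series, on what has been measured and on what is new or still open speak of the compounds shown alone.

Within the data shown here, compound 2 `C/C(=N\NC(=O)c1cccc(S(=O)(=O)N2CCOCC2)c1)c1cc(Br)ccc1O` carries the only real number in this small set: in a functional assay on ECa-109 cells for antiproliferative activity against ECa-109 cell line (Homo sapiens), read by MTT assay, with a stated time of 72 h (on this read-out higher numbers stand for weaker inhibition and lower numbers for stronger inhibition), compound 2 gives 5280 nM. Compound 1 `C/C(=N\NC(=O)c1cccc(S(=O)(=O)N2CCOCC2)c1)c1cccc(O)c1` gives > 100000 nM in this assay, which is a limit of the assay rather than a number. Among the measured compounds shown here, the one measured step, an at least 18-fold lower number from compound 1 to compound 2 (1.27 log units; beyond the scatter), puts 5-bromo-2-hydroxyphenyl in place of 3-hydroxyphenyl on a carbon with a double bond to nitrogen, and its size rests on the limit (the limit of > 100000 nM in this assay, at which 1 of the 2 values shown sits). Compound 3 `C/C(=N\NC(=O)c1cccc(S(=O)(=O)N2CCOCC2)c1)c1cccc(N)c1O` differs from compound 2 by 3-amino-2-hydroxyphenyl in place of 5-bromo-2-hydroxyphenyl on a carbon with a double bond to nitrogen. This change touches the same ring that the measured step changed, where a large step was seen, so a step beyond the scatter is plausible; yet the measured step gives no direction for swapping bromine for an amino group. Compound 3 is therefore expected to sit somewhat weaker, at 20000 nM, ranging from 4000 nM to 100000 nM. The expected step is a 3.8-fold higher number from compound 2 to compound 3 (0.58 log units; beyond the scatter).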

Compound 3, half-maximal inhibitory concentration: 5060 nM
Compound 3: the middle estimate sits 4.0-fold (0.60 log units) above what was measured, within the range that was stated.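

On this carbon with a double bond to nitrogen, 3-amino-2-hydroxyphenyl serves as well as 5-bromo-2-hydroxyphenyl: in this assay the change gives a 1.0-fold lower number from compound 2 to compound 3 (0.02 log units; within the scatter). The bromine is therefore not needed for compound 3 to reach the range of compound 2, and two rings with different added groups cannot be told apart here. Replacing 3-hydroxyphenyl gives a second large step, an at least 19-fold lower number from compound 1 to compound 3 (1.29 log units; beyond the scatter), whose size rests on a limit rather than a number: the limit of > 100000 nM in this assay, at which 1 of the 3 values shown sits.

From the compounds shown here alone, what remains open is whether the plain 2-hydroxyphenyl ring would match compound 2 and compound 3 without any further group. Also open, going by these compounds, are the results for 2-methoxyphenyl, which has a methyl on that oxygen, and for 5-chloro-2-hydroxyphenyl, which has chlorine in place of the bromine.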